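The source may hold more compounds than are shown below. What is called first, only, known or untested is meant among the compounds shown, and "the series" means these compounds.

Of the compounds shown here, three have so far been measured in an assay on HeLa cells with Bile acid receptor (Homo sapiens) as the target, read by a luciferase reporter, with a stated time of 24 h; a lower number here means that less compound is needed, a higher number that more compound is needed for the effect. Compound 1, `O=C(O)c1ccc(CNC(=O)c2cccc(-c3ccccc3)c2)cc1`, gives 670 nM. Compound 2, `C[S+]([O-])c1ccc(CNC(=O)c2ccc(C(C)(C)C)cc2)cc1`, gives 1300 nM. Compound 3, `CC(C)(C)c1ccc(C(=O)NCc2ccc(C(=O)O)cc2Cl)cc1`, gives 7500 nM. Among these three numbers compound 2 stands second highest: its value and that of compound 1 lie within the scatter of each other, so no order can be read between them, whereas compound 3 stands beyond the scatter at the higher number.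

Compound 4, `CC(=O)c1ccc(CNC(=O)c2ccc(C(C)(C)C)cc2)cc1`, has not yet been measured in this assay. It differs from compound 2 in one place: a group of 3 heavy atoms (2 carbon, 1 oxygen; no ring) in place of a group of 3 heavy atoms (1 carbon, 1 oxygen, 1 sulfur; no ring), on an aromatic carbon. The rest of the molecule is kept as in compound 2. Among the compounds with values here, no measured pair in this set shows a change of this kind, so there is no measured step to rest on. The estimated step from compound 2 to compound 4 is therefore a 1.2-fold higher number from compound 2 to compound 4 (0.06 log units; within the scatter), expected to be small, in no firm direction, and not beyond the scatter. Compound 4 is expected to give about 1500 nM in this assay, within a range from 500 nM to 4500 nM.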

Compound 4, half-maximal effective concentration: 100 nM
Beside the measured number, compound 4's estimate is 15-fold (1.18 log units) above it, outside the stated range (below it).
By their numbers in this assay, from the lowest: compound 4; then compounds 1 and 2 (each within the scatter of the next); then compound 3.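

In this assay the aromatic carbon para to a large group proves sensitive to this exchange: with the rest of the molecule kept, acetyl in place of the sulfur-bearing group gives a 13-fold lower number from compound 2 to compound 4 (1.11 log units; beyond the scatter) and is a large step. The two groups have the same counts of heavy atoms, hydrogen-bond donors and hydrogen-bond acceptors, and neither has a ring or a net charge, so these counts do not separate them; they differ in sulfur against carbon and in the double bond that acetyl brings. Nothing available here explains the size of this step.

The compounds shown leave open how a nitrile, an amine or a longer chain would read at this position. They also leave open whether acetyl would give a similar step on the core of compound 1.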